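The source may report more compounds than this note shows. Statements on the series, on what has been measured and on what is new or still open speak of the compounds shown alone.

Measured compounds:
- compound 1 `O=C1Nc2ccccc2/C1=N/NC(=S)Nc1ccc(-n2cccn2)cc1`: > 25000 nM
- compound 2 `Cc1ccc2c(c1)/C(=N/NC(=S)Nc1ccccc1)C(=O)N2`: > 25000 nM
- compound 3 `O=C1Nc2ccccc2/C1=N/NC(=S)N1CCCCC1`: > 25000 nM

In an ADME assay on RD cells (Homo sapiens) for cytotoxicity (a lower number here means that less compound is tolerated, a higher number that more compound is tolerated), compound 1 gives > 25000 nM, which is a limit of the assay and not a number. Compound 2 likewise returns a limit, > 25000 nM. Compound 3 returns a limit as well, > 25000 nM. Among the compounds with values here, all three values therefore sit at the limit of > 25000 nM in this assay, at which 3 of the 3 values shown sit, so compound 1 stands level with the other two measured compounds and no step between measured compounds can be read from these data.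

Compound 4 `O=C1Nc2ccccc2/C1=N/NC(=S)Nc1ccc(Cl)cc1` differs from compound 1 by chloro in place of 1H-pyrazol-1-yl on an aromatic carbon. With every measured value of the series at the limit, the step to compound 4 in this assay is expected to show nothing beyond the scatter, and compound 4 is expected most likely to return a limit again. Compound 4 is estimated at 30000 nM, with a range from 15000 nM to 60000 nM. The expected step is a step that the limit leaves unreadable from compound 1 to compound 4.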

Compound 4, half-maximal cytotoxic concentration: > 25000 nM
Compound 4: a limit, no number (the forecaster's own chance of this, stated with the estimate: 85%); the middle value lies beyond the limit too.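

In this assay, no step can be read from compound 1 to compound 4, as both values are limits and not numbers: the limit of > 25000 nM in this assay, at which 4 of the 4 values shown sit.

The compounds shown leave open the concentration at which any of them reaches half-maximal cytotoxicity, and whether chloro and 1H-pyrazol-1-yl differ at all.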